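A few compounds are considered here, and "the series" means these few. Any claim that something is new, unique, unknown or untested is made for them only; others in the source may bear on it.

In a functional assay on PANC-1 cells (Homo sapiens) for cytotoxicity, read by WST assay, with a stated time of 24 h (on this read-out higher numbers stand for weaker inhibition and lower numbers for stronger inhibition), compound 1 `O=C(/C=C/CCCCC#Cc1ccccc1)N1CCCCC1` gives > 100000 nM, which is a limit. Compound 2 `O=C(CCCCCCc1ccccc1)N1CCCCC1` gives > 100000 nM, also a limit. Compound 3 `Cc1ccc(CCCCCCCCC(=O)N2CCCCC2)cc1` stands at > 100000 nM, again a limit and not a number, so its place in the series is known only as that limit. Compound 4 `O=C(CCCCCCCCc1cccc(Cl)c1)N1CCCCC1` carries 3-chlorophenyl in place of 4-methylphenyl on the same saturated chain carbon: 3-chlorophenyl in place of 4-methylphenyl on a saturated chain carbon, eight bonds along the chain from a carbonyl carbon. For the measured compounds named here, no measured pair shows what this exchange does. The expected change in this assay, a number no higher from compound 3 to compound 4 (the limit leaves the size open), is no step beyond the scatter and no set direction, because of the limit of > 100000 nM in this assay, at which 3 of the 3 values shown sit. For compound 4 the estimate is 100000 nM, with an expected range of 40000 nM to 200000 nM.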

Compound 4, half-maximal inhibitory concentration: > 100000 nM
Compound 4: a limit, no number (the forecaster's own chance of this, stated with the estimate: 80%); the middle value lies on the limit itself.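

No step can be read from compound 3 to compound 4, since both results are limits and not numbers: the limit of > 100000 nM in this assay, at which 4 of the 4 values shown sit.

The compounds shown leave open whether 3-chlorophenyl in place of 4-methylphenyl changes the read-out at all.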